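The source may hold more compounds than are shown below. What is called first, only, known or untested is meant among the compounds shown, and "the series" means these compounds.

Compound 1 `O=C(CCc1cccc2c1B(O)OC2)NC1CCCCC1` gives only a limit in a functional assay on MDA-MB-231 cells (Homo sapiens) for antiproliferative activity, read by MTT assay, with a stated time of 72 h (a lower number here means a stronger inhibitor, a higher number a weaker inhibitor), namely > 100000 nM. Compound 2 `O=C(CCc1cccc2c1B(O)OC2)Nc1ccc(I)cc1` gives 33000 nM in this assay, and compound 3 `O=C(CCc1cccc2c1B(O)OC2)Nc1cccc(I)c1` gives 5300 nM. The measured steps run an at least 3.0-fold lower number from compound 1 to compound 2 (0.48 log units; beyond the scatter), an at least 18-fold lower number from compound 1 to compound 3 (1.27 log units; beyond the scatter) and a 6.2-fold lower number from compound 2 to compound 3 (0.79 log units; beyond the scatter), so compound 3 holds the lowest of the two numbers, with compound 2 nearest and the value of compound 1 being a limit. Compound 4 `COc1cc(OC)cc(-c2cccc(NC(=O)CCc3cccc4c3B(O)OC4)c2)c1` keeps the aryl amide of compound 3 and carries 3,5-dimethoxyphenyl in place of iodo on an aromatic carbon, on an aromatic carbon meta to a large group. Going by the values given here, no measured step covers this exchange; the measured steps show only that an aryl amide beats cyclohexyl and that the 3-iodophenyl beats the 4-iodophenyl. A gain within or just beyond the scatter is therefore expected, a 1.8-fold lower number from compound 3 to compound 4 (0.25 log units; within the scatter). Compound 4 is estimated at 3000 nM, between 800 nM and 12000 nM.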

Compound 4, half-maximal inhibitory concentration: 40 nM
For compound 4 the middle estimate is 75-fold (1.88 log units) above the measured one, and the stated range ends above it.
By their numbers in this assay, from the lowest: compound 4; then compound 3; then compound 2. At a limit, above all of these: compound 1.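

On the aromatic carbon meta to a large group, 3,5-dimethoxyphenyl in place of iodo gives a 130-fold lower number from compound 3 to compound 4 (2.12 log units; beyond the scatter) in this assay and is the only exchange shown at this position. The earlier compounds shown here varied only the group on the amide nitrogen and where the iodo sits, whereas compound 4 shows that this position accepts a whole aromatic ring with a large gain. Nothing measured here accounts for the size of this gain.

The compounds shown leave open whether the gain comes from the added ring or from its methoxy groups. A plain phenyl, or a phenyl carrying an amine or a hydroxyl in their place, lies outside this set.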